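A Sulfur Chain on a Compound Held at the Limit

The source may report more compounds than this note shows. Statements on the series, on what has been measured and on what is new or still open speak of the compounds shown alone.

Compound 1 `CC(C)C[C@H](NC1=CC(=O)C=C(C(C)(C)C)C1=O)C(=O)O` and compound 2 `C[C@H](NC1=CC(=O)C=C(C(C)(C)C)C1=O)C(=O)O` share a core and differ on one saturated chain carbon. In an ADME assay on MRC5 cells (Homo sapiens) for cytotoxicity, read by MTT assay, with a stated time of 72 h (on this read-out higher numbers stand for weaker inhibition and lower numbers for stronger inhibition), compound 1 gives > 200000 nM, which is a limit and not a number. In this assay, compound 2 gives > 200000 nM, also a limit and not a number, so compound 2 has no exact position on the scale. The evidence so far is therefore (the limit of > 200000 nM in this assay, at which 2 of the 2 values shown sit).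

Compound 3 `CSCC[C@H](NC1=CC(=O)C=C(C(C)(C)C)C1=O)C(=O)O` is compound 2 with one change: (methylsulfanyl)methyl in place of hydrogen on a saturated chain carbon, two bonds along the chain from an amine nitrogen and a carbonyl carbon. In words, (methylsulfanyl)methyl takes the place of hydrogen on a saturated chain carbon, two bonds along the chain from an amine nitrogen and a carbonyl carbon. Going by the values given here, the only measured step at this place is a step that the two limits leave unreadable from compound 1 to compound 2, and it offers no size to carry over. No step beyond the usual scatter is therefore expected in this assay, and no direction can be named. The expected step is a number no higher from compound 2 to compound 3 (the limit leaves the size open). Compound 3 is estimated at 200000 nM, with an expected range from 100000 nM to 400000 nM, and the assay may well report only a limit again.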

Compound 3, half-maximal inhibitory concentration: > 200000 nM
Compound 3 ended at the assay's limit; the forecaster's own chance of this, stated with the estimate: 80%; the middle value lies on the limit itself.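

Going by these compounds alone, compound 3 also stands at a limit in this assay, so no step among compound 1, compound 2 and compound 3 can be read. The compounds shown leave open where any of them sits on the scale, and whether changing the group on this saturated chain carbon moves the read-out at all: the limit of > 200000 nM in this assay, at which 3 of the 3 values shown sit.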